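From 4-methoxyphenyl to 3-methoxyphenyl on a sulfur-bound chain

The compounds below may be only part of what the source reports. "The series", "measured", "known", "first", "only" and "open" are said of these compounds alone.

In a functional assay on DU-145 cells (Homo sapiens) for cytotoxicity, read by MTT assay (a lower number here means a stronger inhibitor, a higher number a weaker inhibitor), compound 1 `COc1ccc(CSc2nnc([C@@H](C)c3ccc4cc(OC)ccc4c3)n2-c2ccc(Cl)cc2)cc1` gives 72600 nM. Compound 2 `COc1ccc(CSc2nnc([C@@H](C)c3ccc4cc(OC)ccc4c3)n2-c2ccc(F)cc2)cc1` has only a limit in this assay, <= 400000 nM, and so has no number of its own.

Compound 3 `COc1cccc(CSc2nnc([C@@H](C)c3ccc4cc(OC)ccc4c3)n2-c2ccc(F)cc2)c1` differs from compound 2 in one place: 3-methoxyphenyl in place of 4-methoxyphenyl on a saturated chain carbon bound to a sulfur. Here 3-methoxyphenyl stands in place of 4-methoxyphenyl on a saturated chain carbon bound to a sulfur.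

Among the measured compounds shown here, the one measured step nearby, a step that the limit leaves unreadable from compound 1 to compound 2, is a different change, fluoro in place of chloro on an aromatic carbon, and its size cannot be read. For the measured compounds named here, no measured step covers the exchange of methoxyphenyl groups, so the data give no size or direction for it.

Going by the values given here, the only number available as an anchor is that of compound 1, at 72600 nM. No shift beyond the usual scatter is expected in this assay, in either direction. The estimated step is a step that the limit leaves unreadable from compound 2 to compound 3. Compound 3 is expected at 60000 nM, within an estimated range from 15000 nM to 240000 nM.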

Compound 3, half-maximal inhibitory concentration: 19200 nM
Estimate against measurement, compound 3: 3.1-fold (0.49 log units) above; the measured number falls inside the stated range.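

No size can be read for the step from compound 2 to compound 3, or for the step from compound 1 to compound 2, because compound 2 carries only a limit and not a number: the limit of <= 400000 nM in this assay, at which 1 of the 3 values shown sits.

The compounds shown leave open how 3-methoxyphenyl and 4-methoxyphenyl compare on a saturated chain carbon bound to a sulfur in this assay.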